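The compounds below may be only part of what the source reports. "The series", "measured", "known", "first", "only" and "open" are said of these compounds alone.

Compound 1 `Cc1cc(C(=O)O)ccc1OCCCCOc1ccc(C(=O)CC(C)C)c(O)c1C` gives 42.1% in an assay on HEK293 cells for positive allosteric modulation of metabotropic glutamate receptor 3 (Rattus norvegicus), read by thallium flux, with a stated time of 2.5 min; a higher number here means a larger maximal response, a lower number a smaller maximal response. Compound 2 `Cc1c(OCCCCOc2ccc(C(=O)O)cc2Cl)ccc(C(=O)CC(C)C)c1O` gives 62.9% in this assay; the step of a number 20.8 percentage points higher from compound 1 to compound 2 (beyond the scatter) goes with chloro in place of methyl on an aromatic carbon. Compound 3 `Cc1cc(OCCCCOc2ccc(C(=O)CC(C)C)c(O)c2C)ccc1C(=O)O` gives 41.9% in this assay; it differs from compound 1 by 4-carboxy-3-methylphenyl in place of 4-carboxy-2-methylphenyl on an oxygen on a saturated carbon, and a number 0.2 percentage points lower from compound 1 to compound 3 (within the scatter). Against compound 2, a number 21 percentage points lower from compound 2 to compound 3 (beyond the scatter). Compound 4 `Cc1c(OCCCCOc2ccc(C(=O)O)c(Cl)c2)ccc(C(=O)CC(C)C)c1O` is not yet measured; it differs from compound 3 by chloro in place of methyl on an aromatic carbon. This is the same kind of change as from compound 1 to compound 2, but not the same: in compound 4 the chloro sits ortho to a carboxy group and meta to a large group, whereas in compound 2 it sits ortho to a large group and meta to a carboxy group. Because a number 20.8 percentage points higher from compound 1 to compound 2 (beyond the scatter) an upward step is expected here too, yet the differing place makes a smaller step of a number 11.1 percentage points higher from compound 3 to compound 4 (beyond the scatter) the expectation. Compound 4 is thus estimated at 53%, between 38% and 70%.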

Compound 4, largest response reached (reported as percent of maximum), in percent of the reference or control that the assay uses: 49.5%
For compound 4 the middle estimate is 3.5 percentage points above the measured one; the measured number falls inside the stated range.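

Chloro in place of methyl gives a number 7.6 percentage points higher from compound 3 to compound 4 (within the scatter) in this assay, and the size of this step does not separate the two cores: the same change on two cores in this assay, a number 20.8 percentage points higher (beyond the scatter) from compound 1 to compound 2 and a number 7.6 percentage points higher (within the scatter) from compound 3 to compound 4, 13.2 percentage points apart, within the scatter of two such steps

Where the chloro sits does matter between the two chloro compounds, with a number 13.4 percentage points lower from compound 2 to compound 4 (beyond the scatter), while the swap of the whole ring substituent gives a number 7.4 percentage points higher from compound 1 to compound 4 (within the scatter). The change may therefore carry over from one core to the other, but two pairs cannot show that its size holds, and the newer step alone stays inside the scatter.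

Going by these compounds, it remains open how a fluoro or a methoxy would behave in place of the chloro. Also open, on these data alone, is whether an amide could stand in for the carboxy group, or how a shorter linking chain would change the response.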